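The source may hold more compounds than are shown below. What is called first, only, known or untested is meant among the compounds shown, and "the series" means these compounds.

Working notes on the series. The shared core of compound 1 `c1ccc(-c2ccc(Cc3cccnc3)cn2)cc1` carries a pyridin-3-yl group; in an in vitro assay on V79MZh cells for inhibition of cytochrome P450 11B2, mitochondrial (Homo sapiens) (a higher number here means a weaker inhibitor, a lower number a stronger inhibitor), compound 1 gives 322 nM. Compound 2 `c1ccc(-c2ccc(Cc3ccncc3)cn2)cc1` has pyridin-4-yl instead and gives 621 nM in this assay. Compound 3 `Cc1ccncc1Cc1ccc(-c2ccccc2)nc1` adds a methyl to the shared core; in this assay compound 3 gives 19 nM. Among these three numbers compound 1 stands second highest: the step of a 1.9-fold higher number from compound 1 to compound 2 (0.29 log units; within the scatter) stays within the scatter, whereas the step of a 17-fold lower number from compound 1 to compound 3 (1.23 log units; beyond the scatter) is large.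

Compound 4 `FC(F)(F)c1cncc(Cc2ccc(-c3ccccc3)nc2)c1` differs from compound 1 by trifluoromethyl in place of hydrogen on an aromatic carbon. Among the compounds with values here, the only measured step that puts a group on an aromatic carbon of the core is the one from compound 1 to compound 3, a methyl, and it gave a large drop in number; the trifluoromethyl of compound 4, however, enters at a different aromatic carbon, two atoms from the ring nitrogen and meta to a large group, so no measured step addresses that place directly. The step from compound 1 to compound 2 shows that shifting the ring nitrogen changed little. On this basis the expected step of a 1.3-fold lower number from compound 1 to compound 4 (0.11 log units; within the scatter) is small, with wide uncertainty in either direction. Compound 4 is therefore estimated at 250 nM in this assay, with a range from 60 nM to 1000 nM.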

Compound 4, half-maximal inhibitory concentration: 1120 nM
Compound 4: the middle estimate sits 4.5-fold (0.65 log units) below what was measured; the whole stated range lies below it.
By their numbers in this assay, from the lowest: compound 3; then compounds 1, 2 and 4 (each within the scatter of the next, the first and the last beyond it).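

In this assay, trifluoromethyl in place of hydrogen on an aromatic carbon, two atoms from the ring nitrogen and meta to a large group, gives a 3.5-fold higher number from compound 1 to compound 4 (0.54 log units; beyond the scatter), so this place on the ring tolerates this change less well than the parent hydrogen. Within the data shown here, it also shows that adding a group to this ring does not in itself lower the number: the only earlier step of this kind, a 17-fold lower number from compound 1 to compound 3 (1.23 log units; beyond the scatter), ran the opposite way, but with a methyl at a different aromatic carbon, so group and place both differ between the two steps. Nothing measured here bears on what lies behind the rise in the number.

The compounds shown leave open whether the rise belongs to trifluoromethyl itself or to this place, a question that a methyl, a chlorine, a nitrile or an amine on this same aromatic carbon would help to settle. Also open, from the compounds shown here alone, is how trifluoromethyl would behave on the aromatic carbon that carries the methyl in compound 3.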